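Efficacy notes on a piperidinylpropyl-indole series

A few compounds are considered here, and "the series" means these few. Any claim that something is new, unique, unknown or untested is made for them only; others in the source may bear on it.

Three compounds of the shared core have numbers in a functional assay on CHO cells for activation of 5-hydroxytryptamine receptor 1D (Homo sapiens), read by GTPgammaS binding; on this read-out higher numbers stand for larger maximal responses and lower numbers for smaller maximal responses. Compound 1 `c1ccc(CNCC2CCN(CCCc3c[nH]c4ccc(-n5cnnc5)cc34)CC2)cc1` reaches 101% in this assay. Compound 2 `c1ccc(C2CCCCN2C2CCN(CCCc3c[nH]c4ccc(-n5cnnc5)cc34)CC2)cc1` reaches 65%. Compound 3 `CC(=O)Nc1ccc(CNC2CCN(CCCc3c[nH]c4ccc(-n5cnnc5)cc34)CC2)cc1` reaches 75%, which places compound 3 second highest of the three: the gap to compound 2 lies within the scatter, the gap to compound 1 lies beyond it, so compound 3 is clearly below compound 1 and not distinguishable from compound 2.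

Compound 4 `CC(CO)(NC1CCN(CCCc2c[nH]c3ccc(-n4cnnc4)cc23)CC1)c1ccccc1` has not been measured in this assay. It differs from compound 3 in one place: 1-(hydroxymethyl)-1-phenylethyl in place of 4-acetamidobenzyl on an amine nitrogen. No step between two measured compounds mirrors this change, so its size cannot be read off other pairs. Given that all three measured members of the series reach substantial responses, the step from compound 3 is expected to be small, with no direction favoured beyond the scatter, a number 3 percentage points lower from compound 3 to compound 4 (within the scatter). In this assay compound 4 is therefore estimated at 72%, with a plausible range from 50% to 95%.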

Compound 4, largest response reached (reported as efficacy), in percent of the reference or control that the assay uses: 59%
Beside the measured number, compound 4's estimate is 13 percentage points above it; measured number inside the range.
By their numbers in this assay, from the lowest: compounds 4, 2 and 3 (each within the scatter of the next, the first and the last beyond it); then compound 1.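

In this assay, for the compounds shown here, the substituent on this amine nitrogen affects the maximal response: 1-(hydroxymethyl)-1-phenylethyl in place of 4-acetamidobenzyl gives a number 16 percentage points lower from compound 3 to compound 4 (beyond the scatter), the first step that can be read at this position. On a saturated ring carbon, (1-(hydroxymethyl)-1-phenylethyl)amino in place of (benzylamino)methyl gives a number 42 percentage points lower from compound 1 to compound 4 (beyond the scatter), a larger step for a change that alters more of the side chain. Nothing shown here accounts for either step.

Open, going by these compounds, is how the hydroxymethyl and the methyl of the new group each contribute, which a 1-phenylethyl or a plain benzyl on the same amine nitrogen would help to separate. Also open, on these data alone, is whether an amide or a carboxylic acid at this position would keep the response.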